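The compounds below may be only part of what the source reports. "The series", "measured", "known", "first", "only" and "open" are said of these compounds alone.

Compound 1 `c1ccc(COc2cccc(-c3cn(C4CN5CCC4CC5)nn3)c2)cc1` gives 668 nM in an assay on HEK293 cells for displacement of a labelled ligand from Neuronal acetylcholine receptor; alpha4/beta2 (Homo sapiens), read by scintillation counting, with a stated time of 120 min (a lower number here means a stronger inhibitor, a higher number a weaker inhibitor), the second highest of the three numbers in hand. Its nearest neighbour is compound 2 `c1ccc(COc2cccc(-c3cn([C@@H]4CN5CCC4CC5)nn3)c2)cc1` at 414 nM, and the step of a 1.6-fold lower number from compound 1 to compound 2 (0.21 log units; within the scatter) turns only on the fact that (the fact that one of compounds 1 and 2 is drawn with a defined configuration and the other without, at the place where they differ). Compound 3 `Fc1ccc(-c2cn([C@H]3CN4CCC3CC4)nn2)cc1` lies far off at 10400 nM, but it differs from compound 1 in more than one place, so no single step can be read from that pair.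

Compound 4 `FCCCOc1cccc(-c2cn(C3CN4CCC3CC4)nn2)c1` carries the change (2-fluoroethyl in place of phenyl on a saturated chain carbon bound to an oxygen on an aromatic ring). For the measured compounds named here, no measured step touches the part of the core that changes here, so no direction can be expected from the data, and the change of compound 1 is taken to leave the number roughly where it is. Compound 4 is therefore estimated at 800 nM, with a range of 200 nM to 3200 nM, the expected step being a 1.2-fold higher number from compound 1 to compound 4 (0.08 log units; within the scatter).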

Compound 4, inhibition constant: 3890 nM
Beside the measured number, compound 4's estimate is 4.9-fold (0.69 log units) below it; measured number outside the range, above it.
By their numbers in this assay, from the lowest: compounds 2 and 1 (each within the scatter of the next); then compound 4; then compound 3.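

For the compounds shown here, the position on the oxygen is sensitive to what it carries: in this assay, replacing the phenyl with 2-fluoroethyl gives a 5.8-fold higher number from compound 1 to compound 4 (0.77 log units; beyond the scatter), the only single-place step that lies beyond the scatter. This pair alone favours benzyloxy over 3-fluoropropoxy, and it does not establish a trend across the series. No measured fact in hand bears on the cause of this step.

As far as these compounds go, whether the higher number follows from losing the aromatic ring or from gaining the fluorine remains open. An unfluorinated propyl chain and a fluorobenzyl group would help separate those two changes.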